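Methyl for Chloro: Expected Loss in Growth Inhibition

The source may report more compounds than this note shows. Statements on the series, on what has been measured and on what is new or still open speak of the compounds shown alone.

Measured compounds:
compound 1 `Cc1ccc2c(c1)CCCN2c1nc(Cl)nc2ccccc12` gives 48 nM in a functional assay on KB cells (Homo sapiens) for cytotoxicity, read by sulforhodamine B assay; a lower number here means a stronger inhibitor of growth, a higher number a weaker inhibitor of growth
compound 2 `Cc1ccc2c(c1)CCCN2c1nc(C)nc2ccccc12` gives 204 nM in this assay
compound 3 `COc1ccc2c(c1)CCN2c1nc(Cl)nc2ccccc12` gives 227 nM in this assay

Compound 4 `COc1ccc2c(c1)CCN2c1nc(C)nc2ccccc12` has not yet been measured in this assay. It stands to compound 3 as compound 2 stands to compound 1: compound 2 differs from compound 1 by methyl in place of chloro on an aromatic carbon, and compound 4 differs from compound 3 by methyl in place of chloro on an aromatic carbon, the same change at the same place. How the core of compound 1 differs from that of compound 3 is not broken down here. The measured step is a 4.3-fold higher number from compound 1 to compound 2 (0.63 log units; beyond the scatter). Compound 3 itself gives a higher number than compound 1 in this assay, beyond the scatter, while compound 3 and compound 2 lie within the scatter of each other. Among the compounds with values here, because the single measured instance shows a 4.3-fold higher number from compound 1 to compound 2 (0.63 log units; beyond the scatter), a step of similar size is expected here, a 4.2-fold higher number from compound 3 to compound 4 (0.62 log units; beyond the scatter). Compound 4 is therefore estimated at 950 nM in this assay, expected to fall between 400 nM and 2500 nM.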

Compound 4, concentration for 50% growth inhibition: 320 nM
The estimate for compound 4 lay 3.0-fold (0.47 log units) above the measured number; the measured number lies below the stated range.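

In this assay, putting methyl in place of chloro on the core of compound 3 gave a 1.4-fold higher number from compound 3 to compound 4 (0.15 log units; within the scatter). The size of the step did not carry over from the core of compound 1 to the core of compound 3: the same change on two cores in this assay, a 4.3-fold higher number (0.63 log units; beyond the scatter) from compound 1 to compound 2 and a 1.4-fold higher number (0.15 log units; within the scatter) from compound 3 to compound 4, 3.0-fold (0.48 log units) apart, beyond the scatter of two such steps. These two pairs show that the step seen on one core cannot simply be assumed on the other, but they do not show which difference between the cores goes with the gap, or what the change would do on any further core.

The compounds shown leave open how other groups at this aromatic carbon, such as an amine or a nitrile, would compare with chloro and methyl on either core.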